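Bromine on the triazole-linked phenyl ring: expected potency

This account rests on a few compounds, and the source may have more. Where it says the series, first, only, none or still open, it means among the compounds named here.

In a functional assay on HepG2 cells (Homo sapiens) for inhibition, read by MTT assay, with a stated time of 72 h (on this read-out lower numbers stand for stronger inhibition and higher numbers for weaker inhibition), compound 2 `COc1ccc(-n2cc(COc3cccc(NC(=O)Nc4ccc(Cl)c(C(F)(F)F)c4)c3)nn2)cc1` gives 4680 nM, the highest number among the three measured compounds. Compound 1 `COc1cccc(-n2cc(COc3cccc(NC(=O)Nc4ccc(Cl)c(C(F)(F)F)c4)c3)nn2)c1` gives 1310 nM and compound 3 `O=C(Nc1cccc(OCc2cn(-c3cccc(F)c3)nn2)c1)Nc1ccc(Cl)c(C(F)(F)F)c1` gives 2120 nM. The step of a 3.6-fold higher number from compound 1 to compound 2 (0.55 log units; beyond the scatter) and the step of a 2.2-fold lower number from compound 2 to compound 3 (0.34 log units; beyond the scatter) both set compound 2 apart, while the step of a 1.6-fold higher number from compound 1 to compound 3 (0.21 log units; within the scatter) shows that 3-methoxyphenyl and 3-fluorophenyl behave alike on this read-out.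

Compound 4 `O=C(Nc1cccc(OCc2cn(-c3cccc(Br)c3)nn2)c1)Nc1ccc(Cl)c(C(F)(F)F)c1` differs from compound 2 in one place: 3-bromophenyl in place of 4-methoxyphenyl on an aromatic nitrogen. Among the measured compounds shown here, the closest precedent is the change from compound 2 to compound 3, in which another 3-substituted phenyl replaced 4-methoxyphenyl and gave a modest lower number; the step from compound 1 to compound 2 points the same way. A lower number of a size near that precedent is therefore expected for compound 4 in this assay. The expected step is a 2.3-fold lower number from compound 2 to compound 4 (0.37 log units; beyond the scatter). Compound 4 is estimated at 2000 nM, with a range from 900 nM to 4500 nM.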

Compound 4, half-maximal inhibitory concentration: 1040 nM
The estimate for compound 4 lay 1.9-fold (0.28 log units) above the measured number; the range from low to high includes it.
By their numbers in this assay, from the lowest: compounds 4, 1 and 3 (each within the scatter of the next, the first and the last beyond it); then compound 2.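

In this assay, a 4.5-fold lower number from compound 2 to compound 4 (0.65 log units; beyond the scatter) extends the gap that already set 4-methoxyphenyl apart, and all three 3-substituted phenyl compounds now lie beyond the scatter from compound 2. Among the compounds shown here, the halogen also matters for the first time: a 2.0-fold lower number from compound 3 to compound 4 (0.31 log units; beyond the scatter), with bromo in place of fluoro, lies beyond the scatter, while a 1.3-fold lower number from compound 1 to compound 4 (0.10 log units; within the scatter), with bromo in place of methoxy, stays within it. No measurement shown accounts for these differences.

Because 4-methoxyphenyl is the only 4-substituted phenyl here, the compounds cannot show whether the higher number of compound 2 belongs to that placement generally or to methoxy alone. As far as these compounds go, how an amine or a carboxylic acid on this phenyl ring would behave also remains open.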